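The source may hold more compounds than are shown below. What is called first, only, known or untested is meant among the compounds shown, and "the series" means these compounds.

Measured compounds in a functional assay for agonist activity at Alpha-1B adrenergic receptor (Homo sapiens); on this read-out higher numbers stand for an effect only at larger amounts of compound and lower numbers for an effect already at smaller amounts:
compound 1 `COc1ccc(S(C)(=O)=O)c(NCC2=NCCN2)c1` — compound 1 gives < 100000 nM, a limit of the assay rather than a number.
compound 2 `CS(=O)(=O)c1ccc(F)cc1NCC1=NCCN1` — compound 2 gives < 100000 nM, likewise a limit.

Among the measured compounds shown here, compound 2 thus stands only at a limit in this assay; the one further value shown, that of compound 1, is a limit as well (the limit of < 100000 nM in this assay, at which 2 of the 2 values shown sit). The step from compound 1 to compound 2, fluoro in place of methoxy on an aromatic carbon, is a step that the two limits leave unreadable from compound 1 to compound 2.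

Compound 3 `CS(=O)(=O)c1ccc(Cl)cc1NCC1=NCCN1` differs from compound 2 by chloro in place of fluoro on an aromatic carbon. For the measured compounds named here, no measured step gives a readable size for this change, since the only step is unreadable because both of its values sit at the limit (the limit of < 100000 nM in this assay, at which 2 of the 2 values shown sit). No step beyond the scatter can therefore be expected in this assay, in either direction, and a limit may again be all that is reported. Compound 3 is estimated at 20000 nM, within 1000 nM to 100000 nM. The step from compound 2 to compound 3 that this estimate means is a step that the limit leaves unreadable from compound 2 to compound 3, expected within the scatter.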

Compound 3, half-maximal effective concentration: 61.7 nM
The estimate for compound 3 lay 320-fold (2.51 log units) above the measured number; the measured number lies below the stated range.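

Neither step to compound 3, from compound 1 or from compound 2, can be read, because each sets a measured number against a limit: the limit of < 100000 nM in this assay, at which 2 of the 3 values shown sit.

The compounds shown leave open how large the changes to chloro from fluoro and from methoxy are.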